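The source may hold more compounds than are shown below. What is called first, only, known or untested is meant among the compounds shown, and "the series" means these compounds.

Measured so far in a physicochemical assay for solubility, at pH 6.5; on this read-out lower numbers stand for lower solubility and higher numbers for higher solubility:
Compound 2 `CS(=O)(=O)c1cccc(-c2ccc3ncc(-c4ccc(S(=O)(=O)CCCN)cc4)n3n2)c1` gives 180000 nM.
Compound 1 `CS(=O)(=O)c1cncc(-c2cnc3ccc(-c4cccc(S(=O)(=O)C5CC5)c4)nn23)c1` gives only a limit of the assay, < 5000 nM.
Compound 3 `C[S+]([O-])c1cccc(-c2ccc3ncc(-c4ccc(C(N)=O)cc4)n3n2)c1` gives only a limit of the assay, < 5000 nM.

Going by the values given here, compound 2 is thus the one compound here with an actual number; compound 1 and compound 3 stand at the limit of < 5000 nM in this assay, at which 2 of the 3 values shown sit, so no measured step between compounds is available. Compound 4 `CS(=O)(=O)c1cccc(-c2ccc3ncc(-c4ccc(S(=O)(=O)N5CCNCC5)cc4)n3n2)c1` differs from compound 2 by piperazin-1-yl in place of 3-aminopropyl on a sulfonyl sulfur. Without a comparable measured step, the account expects a modest fall in this assay from compound 2 to compound 4, about at the edge of the usual scatter rather than clearly beyond it: a 2.0-fold lower number from compound 2 to compound 4 (0.30 log units; within the scatter). Compound 4 is therefore estimated at 90000 nM, within a range of 25000 nM to 300000 nM.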

Compound 4, solubility: 162000 nM
The estimate for compound 4 lay 1.8-fold (0.26 log units) below the measured number, within the range that was stated.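

In this assay, going by these compounds alone, this gives the first readable step at this position: a 1.1-fold lower number from compound 2 to compound 4 (0.05 log units; within the scatter). On a sulfonyl sulfur, the six-membered ring of piperazin-1-yl and the open chain of 3-aminopropyl thus read alike. Compound 4, like compound 2, gives an actual number rather than a limit, which is not true of every compound here: the limit of < 5000 nM in this assay, at which 2 of the 4 values shown sit.

The compounds shown leave open whether a plain propyl chain or a carboxylic acid on the same sulfonyl sulfur would read alike too. They also leave open whether a longer amine chain would do so.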